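The source may hold more compounds than are shown below. What is called first, only, known or untested is meant among the compounds shown, and "the series" means these compounds.

Measured so far in an assay on isolated protein for inhibition of Aromatase (Homo sapiens), read by fluorescence and colorimetric assay, with a stated time of 30 min; a lower number here means a stronger inhibitor, a higher number a weaker inhibitor:
compound 1 `N#Cc1ccc(C(c2ccc(C#N)cc2)n2cc(COc3ccc(-c4ccccc4)cc3)nn2)cc1` gives 13400 nM
compound 2 `c1ccc(C(c2ccccc2)n2ccnn2)cc1` gives 4580 nM

Compound 2 holds the lower of the two numbers in this assay; compound 1 sits well beyond the scatter above it. Compound 3 `c1ccc(-c2cn(C(c3ccccc3)c3ccccc3)nn2)cc1` carries phenyl in place of hydrogen on an aromatic carbon on the core of compound 2. Going by the values given here, no measured pair shows this change, so the direction rests on expectation alone: compound 3 is expected to stay close to compound 2, with a step of a 1.5-fold lower number from compound 2 to compound 3 (0.18 log units; within the scatter) that may not reach beyond the scatter. Compound 3 is therefore estimated at 3000 nM, within a range from 800 nM to 12000 nM.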

Compound 3, half-maximal inhibitory concentration: 12900 nM
Compound 3: the middle estimate sits 4.3-fold (0.63 log units) below what was measured, outside the stated range (above it).
By their numbers in this assay, from the lowest: compound 2; then compounds 3 and 1 (each within the scatter of the next).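

In this assay, phenyl in place of hydrogen on an aromatic carbon of the five-membered aromatic ring with 3 nitrogen gives a 2.8-fold higher number from compound 2 to compound 3 (0.45 log units; beyond the scatter). This position, two ring bonds from the ring atom that bears a large group, therefore responds to substitution, and of the two groups compared here, hydrogen gives the stronger inhibitor. Nothing available explains the step.

From the compounds shown here alone, whether the loss is specific to phenyl stays open. A methyl group, an amine or a carboxylic acid on this carbon would show whether other groups behave the same way.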